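The compounds below may be only part of what the source reports. "The series", "measured", "known", "first", "only" and "open" are said of these compounds alone.

Compound 2 `COc1cc(-c2nn(-c3cccc(NC(=O)c4cccc(C(F)(F)F)c4)c3)cc2-c2ccncc2)ccc1Cl`: 1320 nM
Compound 1 `O=C(Nc1cccc(-n2cc(-c3ccncc3)c(-c3ccc(Cl)c(O)c3)n2)c1)Nc1cccc(C(F)(F)F)c1`: 980 nM
Compound 3 `O=C(Nc1cccc(-n2cc(-c3ccncc3)c(-c3ccc(Cl)c(O)c3)n2)c1)Nc1cc(C(F)(F)F)cc(C(F)(F)F)c1`: 265 nM

In a functional assay on MDA-MB-468 cells (Homo sapiens) for inhibition, read by sulforhodamine B assay, with a stated time of 48 h (on this read-out higher numbers stand for weaker inhibition of growth and lower numbers for stronger inhibition of growth), compound 2 gives the highest of the three numbers; its gap to compound 1 lies within the scatter, while compound 3 lies well beyond it. Compound 4 `COc1cc(-c2nn(-c3cccc(NC(=O)Nc4ccc(Cl)c(C(F)(F)F)c4)c3)cc2-c2ccncc2)ccc1Cl` differs from compound 2 by (4-chloro-3-(trifluoromethyl)phenyl)amino in place of 3-(trifluoromethyl)phenyl on a carbonyl carbon. Within the data shown here, no measured step matches this change. Among the measured compounds shown here, the only step available, a 3.7-fold lower number from compound 1 to compound 3 (0.57 log units; beyond the scatter), shows that adding a trifluoromethyl to the tail ring gave a modest gain; compound 4 also gains a halogen on that ring, so a modest lowering of the number is expected, though with little support. Compound 4 is estimated at 450 nM (150 nM to 1300 nM), a step of a 2.9-fold lower number from compound 2 to compound 4 (0.47 log units; beyond the scatter).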

Compound 4, concentration for 50% growth inhibition: 833 nM
Estimate against measurement, compound 4: 1.9-fold (0.27 log units) below; the measured number falls inside the stated range.
By their numbers in this assay, from the lowest: compound 3; then compounds 4, 1 and 2 (each within the scatter of the next).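

In this assay, the change on this carbonyl carbon brings in a chlorine and an amino nitrogen together, yet it gives a 1.6-fold lower number from compound 2 to compound 4 (0.20 log units; within the scatter) and so does not separate the two compounds. The earlier trifluoromethyl addition, by contrast, gave a step beyond the scatter (a 3.7-fold lower number from compound 1 to compound 3 (0.57 log units; beyond the scatter)), so not every addition to this tail ring moves the number clearly. No available measurement offers a reason for this result. The compounds shown leave open what the chlorine and the amino nitrogen each contribute alone, and whether a nitrile or a methyl in place of that chlorine would read differently.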